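Notes on the isobutyl to propyl step

The compounds below may be only part of what the source reports. "The series", "measured", "known", "first", "only" and "open" are said of these compounds alone.

- compound 1 `CCC[C@@H]1O[C@H](COCc2ccccc2)[C@@H](OCc2ccccc2)[C@H](OCc2ccccc2)[C@H]1O` gives 11700 nM
- compound 2 `CC(C)C[C@H]1O[C@H](COCc2ccccc2)[C@H](OCc2ccccc2)[C@H](OCc2ccccc2)[C@H]1O` gives "not active" (no number reported)

In a functional assay on HL-60 cells (Homo sapiens) for antiproliferative activity, read by MTT assay (on this read-out higher numbers stand for weaker inhibition and lower numbers for stronger inhibition), compound 2 has no place on the numerical scale (reported as "not active" (no number reported)) and no number is given for it. Going by the values given here, compound 1 gives the only number so far (11700 nM). The compound to be measured next is compound 3 `CCC[C@H]1O[C@H](COCc2ccccc2)[C@H](OCc2ccccc2)[C@H](OCc2ccccc2)[C@H]1O` and one change leads to it: hydrogen in place of methyl on a saturated chain carbon bound to two saturated chain carbons with hydrogen in place of methyl on a saturated chain carbon bound to two saturated chain carbons, which reads as isobutyl to propyl. Among the compounds with values here, no measured step supports a size for this change in this assay. A move towards stronger inhibition is expected, from no number to a weak but measurable value, though compound 3 may also give no number. Compound 3 is expected at 20000 nM with a range from 8000 nM to 60000 nM as estimated.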

Compound 3, half-maximal inhibitory concentration: "not active" (no number reported)
The entry for compound 3 holds no number, so the estimate cannot be set against anything.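

Compound 2 and compound 3 both stay without a number in this assay, so no step can be read for the change from isobutyl to propyl. What stays open is whether configuration alone separates compound 3 from compound 1, which gives 11700 nM, and the one pointer to this is: the fact that compounds 1 and 3 differ only in the configuration as drawn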